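Methyl scan on the quinoline-type core of compound 1

The source may report more compounds than this note shows. Statements on the series, on what has been measured and on what is new or still open speak of the compounds shown alone.

The series rests on two measured compounds. Compound 1 `Cc1ccc2c(O)cc(-c3cccc(Cl)c3)nc2n1` was run in a functional assay on NSCLC cells (Homo sapiens) for inhibition (on this read-out lower numbers stand for stronger inhibition of growth and higher numbers for weaker inhibition of growth), and gives 24500 nM. Compound 2 `Cc1cnc2[nH]c(-c3cccc(Cl)c3)cc(=O)c2c1`, which carries the same chloro-aryl group on a core with a ring amide instead of the hydroxyl, gives 44700 nM in this assay. Compound 1 holds the smaller of the two numbers, but compound 2 sits within the scatter of it, so the two are not separated by this assay and nothing can be said of a direction between them.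

Compound 3 `Cc1cc(C)c2c(O)cc(-c3cccc(Cl)c3)nc2n1` is not yet measured. It differs from compound 1 only by methyl in place of hydrogen on an aromatic carbon. Within the data shown here, no measured pair shows what this kind of change does, so there is no step on which to lean; the expectation is a step from compound 1 to compound 3 that stays within the usual scatter, with no preferred direction. Compound 3 is therefore estimated at 22000 nM, within 8000 nM to 60000 nM, which corresponds to an expected step of a 1.1-fold lower number from compound 1 to compound 3 (0.05 log units; within the scatter).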

Compound 3, concentration for total growth inhibition: > 100000 nM
Compound 3: no number, only a limit; the forecaster's own chance of this, stated with the estimate: 5%; at least 4.5-fold (0.65 log units) between middle value and limit.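

In this assay, among these compounds, methyl in place of hydrogen on an aromatic carbon, opposite the ring nitrogen, gives an at least 4.0-fold higher number from compound 1 to compound 3 (0.61 log units; beyond the scatter), the only step that reads beyond the scatter. This position on the core of compound 1 is therefore not indifferent to a single added methyl, something the pair of compound 1 and compound 2 could not show, since those two are not separated by this read-out. Compound 3 reads > 100000 nM, which is a limit of the assay and not a number, so the step has a floor but no known full size: the limit of > 100000 nM in this assay, at which 1 of the 3 values shown sits.

Still open, going by these compounds, is whether a fluorine atom, a methoxy group or an amine on this same aromatic carbon would give a similar loss of growth inhibition in this assay, or whether the result is particular to methyl. On these data alone, with a single step in hand, it is also open whether methyl at the matching place on the core of compound 2 would act in the same way.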